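The source may report more compounds than this note shows. Statements on the series, on what has been measured and on what is new or still open speak of the compounds shown alone.

Working notes on the series. Going by the values given here, compound 2 `CC(=O)Oc1ccc(-c2ccc(F)cc2F)cc1C(=O)Nc1ccc(C)cc1` is the higher of the two numbers in hand: in a functional assay on the whole organism (Ear) for inhibition, with Mus musculus as the target, at a dose of 40 mg/kg by the oral route (on this read-out lower numbers stand for less inhibition and higher numbers for more inhibition at the one dose given (going by the name of the read-out)), compound 2 gives 36.4%, whereas compound 1 `CC(=O)Oc1ccc(-c2ccc(F)cc2F)cc1C(=O)NC1CCCCC1` gives 0%, the one step between them, 4-methylphenyl in place of cyclohexyl on an amide-type nitrogen, being a number 36.4 percentage points higher from compound 1 to compound 2 (beyond the scatter).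

Compound 3 `CC(=O)Oc1ccc(-c2ccc(F)cc2F)cc1C(=O)Nc1cc(C)ccc1C` is not yet measured. Its difference from compound 2 is 2,5-dimethylphenyl in place of 4-methylphenyl on an amide-type nitrogen. Among the compounds with values here, the one measured step does not test this change: it swaps a ring type at the nitrogen, while here an aromatic ring of carbon only remains and only the methyl count and placement differ. Within the data shown here, no measured step bears directly on it.

Since the aromatic ring that came with the large step from compound 1 is kept, compound 3 is expected to stay near compound 2, with a step of a number 6.4 percentage points lower from compound 2 to compound 3 (within the scatter) not expected to exceed the scatter. Compound 3 is therefore estimated at 30%, within 5% to 55%.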

Compound 3, a percentage reported as inhibition, in the whole organism at one dose (the size of the read-out at that dose, not a potency): 22%
Estimate against measurement, compound 3: 8 percentage points above, and the stated range covers the measured number.
By their numbers in this assay, from the lowest: compound 1; then compound 3; then compound 2.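

At this amide-type nitrogen, the difference between two aromatic rings of carbon only also registers in this assay: 2,5-dimethylphenyl in place of 4-methylphenyl gives a number 14.4 percentage points lower from compound 2 to compound 3 (beyond the scatter) and so goes beyond the scatter, which shows that methyl count and placement on the ring matter here and that the aromatic ring alone does not set the number. The gain over cyclohexyl survives this change, with a number 22 percentage points higher from compound 1 to compound 3 (beyond the scatter) and thus beyond the scatter, so both aromatic amides stand above the cyclohexyl amide, by unequal margins. Nothing at hand accounts for either step.

With one dimethylphenyl pattern set against one methylphenyl group, the effect of the second methyl cannot be separated from that of methyl placement. Going by these compounds, whether a methoxy group or a chlorine on the phenyl ring, or an unsubstituted phenyl, would hold or raise the number stays open.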